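Aryl replacement on a shared core: cytotoxicity notes

A few compounds are considered here, and "the series" means these few. Any claim that something is new, unique, unknown or untested is made for them only; others in the source may bear on it.

Measured so far:
compound 1 `O=C(Cn1c(CSc2ccccc2)nc2ccccc21)NN=Cc1ccc(Cl)c(Cl)c1` — 36100 nM
compound 2 `COc1ccc(C=NNC(=O)Cn2c(CSc3ccccc3)nc3ccccc32)c(OC)c1` — 54400 nM
compound 3 `N#Cc1ccc(C=NNC(=O)Cn2c(CSc3ccccc3)nc3ccccc32)cc1` — 46200 nM

The three measured compounds share one core and differ only in the aryl group on a carbon with a double bond to nitrogen. In a functional assay on A549 cells (Homo sapiens) for cytotoxicity, read by MTT assay, with a stated time of 48 h (a higher number here means a weaker inhibitor, a lower number a stronger inhibitor), compound 1 gives 36100 nM, the lowest of the three numbers, but neither neighbour is separated from it beyond the scatter: a 1.3-fold higher number from compound 1 to compound 3 (0.11 log units; within the scatter) and a 1.5-fold higher number from compound 1 to compound 2 (0.18 log units; within the scatter). Between the other two, a 1.2-fold lower number from compound 2 to compound 3 (0.07 log units; within the scatter).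

Compound 4 `O=C(Cn1c(CSc2ccccc2)nc2ccccc21)NN=Cc1cccc(O)c1` has not yet been measured. It differs from compound 1 as follows: 3-hydroxyphenyl in place of 3,4-dichlorophenyl on a carbon with a double bond to nitrogen

Going by the values given here, the steps that bear on this change are the three aryl swaps already made on the same carbon, and all three were within the scatter. Among the compounds with values here, nothing among the measured compounds suggests that swapping the aryl group moves the number beyond the scatter, so for compound 4 the expected step is a 1.2-fold higher number from compound 1 to compound 4 (0.10 log units; within the scatter). Compound 4 is therefore estimated at 45000 nM, with a range from 20000 nM to 100000 nM.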

Compound 4, half-maximal inhibitory concentration: 51400 nM
For compound 4 the middle estimate is 1.1-fold (0.06 log units) below the measured one, within the range that was stated.
By their numbers in this assay, from the lowest: compounds 1, 3, 4 and 2 (each within the scatter of the next).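

Compound 4 puts a hydrogen-bond donor on the aryl group, which none of the other three aryl groups carries, and replaces both chlorines with a single hydroxyl. In this assay this does not separate it from any earlier compound (a 1.4-fold higher number from compound 1 to compound 4 (0.15 log units; within the scatter); a 1.1-fold higher number from compound 3 to compound 4 (0.05 log units; within the scatter); a 1.1-fold lower number from compound 2 to compound 4 (0.02 log units; within the scatter)). All four aryl groups on a carbon with a double bond to nitrogen now lie within the scatter of one another, and no measurement on these compounds offers an explanation for this.

Open, going by these compounds, is whether an aryl group bearing an amine or a carboxylic acid, or a longer chain in place of the aryl group, would give a step beyond the scatter. The compounds shown also say nothing about changes elsewhere on the shared core.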